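Cyclic Sulfonamide in Place of an Amide on a Shared Core

A few compounds are considered here, and "the series" means these few. Any claim that something is new, unique, unknown or untested is made for them only; others in the source may bear on it.

Compound 1 `CC1(C)Oc2ccc(C(=O)Cc3ccccc3)cc2[C@@H](/N=C(\NC#N)Nc2ccc(Cl)cc2)[C@@H]1O`: 6800 nM
Compound 2 `CC1(C)Oc2ccc(C(=O)Nc3ccccc3)cc2[C@@H](/N=C(\NC#N)Nc2ccc(Cl)cc2)[C@@H]1O`: > 100000 nM
Compound 3 `CCN(CC)S(=O)(=O)c1ccc2c(c1)[C@@H](/N=C(\NC#N)Nc1ccc(Cl)cc1)[C@H](O)C(C)(C)O2`: 1100 nM

Three measured compounds share one core and were tested in a functional assay (aorta) with Rattus norvegicus as the target; on this read-out higher numbers stand for weaker inhibition and lower numbers for stronger inhibition. Compound 2 stands apart: its value is only a limit of the assay, not a number, so for compound 2 only a floor is known (the limit of > 100000 nM in this assay, at which 1 of the 3 values shown sits). Of the numbers actually obtained, compound 3 is the lowest, and the step from compound 2 to compound 3 was an at least 90-fold lower number from compound 2 to compound 3 (1.95 log units; beyond the scatter); the step from compound 1 to compound 3 was a 6.2-fold lower number from compound 1 to compound 3 (0.79 log units; beyond the scatter).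

Compound 4 `CC1CC(C)CN(S(=O)(=O)c2ccc3c(c2)[C@@H](/N=C(\NC#N)Nc2ccc(Cl)cc2)[C@H](O)C(C)(C)O3)C1` is not yet measured. It differs from compound 2 by (3,5-dimethylpiperidin-1-yl)sulfonyl in place of phenylcarbamoyl on an aromatic carbon. Within the data shown here, this change resembles the one that turned compound 2 into compound 3: in both, phenylcarbamoyl gives way to a sulfonyl group carrying an amine, here a ring-closed one. The measured steps therefore point to a large drop in this assay. The expected step is an at least 66-fold lower number from compound 2 to compound 4 (1.82 log units; beyond the scatter). Compound 4 is estimated at 1500 nM, within a range from 300 nM to 8000 nM.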

Compound 4, half-maximal inhibitory concentration: 32100 nM
For compound 4 the middle estimate is 21-fold (1.33 log units) below the measured one; measured number above the stated range.
By their numbers in this assay, from the lowest: compound 3; then compound 1; then compound 4. At a limit, above all of these: compound 2.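

In this assay, the amine on the sulfonyl group turns out to matter: 3,5-dimethylpiperidin-1-yl in place of diethylamino gives a 29-fold higher number from compound 3 to compound 4 (1.47 log units; beyond the scatter), so the sulfonyl group alone does not secure a low number at this aromatic carbon. Replacing phenylcarbamoyl with the new sulfonyl group still gives an at least 3.1-fold lower number from compound 2 to compound 4 (0.49 log units; beyond the scatter), but this step starts from a limit of the assay rather than a number. Replacing benzylcarbonyl with it gives a 4.7-fold higher number from compound 1 to compound 4 (0.67 log units; beyond the scatter), the opposite direction to the step with the diethylamino sulfonyl group, so a sulfonyl group is not better than benzylcarbonyl in every case.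

The compounds shown do not separate the effect of closing the ring from that of the two methyl groups, and an unsubstituted piperidin-1-yl on the sulfonyl sulfur would be the missing comparison. How far compound 2 truly lies from the others also stays unknown: the limit of > 100000 nM in this assay, at which 1 of the 4 values shown sits.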